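Solubility notes: amide side chain swap in compound 2

The source may hold more compounds than are shown below. What is called first, only, known or untested is meant among the compounds shown, and "the series" means these compounds.

Compound 2 `O=C(NCCO)c1ccc2ccc(C(=O)c3ccccc3)c-2cc1` has been measured in a physicochemical assay for solubility, with a stated time of 24 h, at pH 4.5 (a lower number here means a less soluble compound, a higher number a more soluble compound), where compound 2 gives 6 ug/mL, the highest of the two numbers available, with compound 3 `O=C(Nc1cc2cccccc-2c1)c1cccnc1` nearest at 3 ug/mL, a gap within the scatter. Compound 1 `c1cc2ccc(CN3CCCCC3)ccc-2c1` reaches only a limit in this assay, > 56 ug/mL (the limit of > 56 ug/mL in this assay, at which 1 of the 3 values shown sits). Compound 4 `O=C(NCc1cccnc1)c1ccc2ccc(C(=O)c3ccccc3)c-2cc1` has not yet been measured in this assay. It differs from compound 2 by pyridin-3-yl in place of hydroxymethyl on a saturated chain carbon bound to an amide-type nitrogen. Within the data shown here, no measured pair differing in one place covers this change, so its size is open. The expectation is a step of a 1.3-fold higher number from compound 2 to compound 4 (0.12 log units; within the scatter) that stays within the scatter, leaning slightly upward. Compound 4 is thus expected to show a solubility near 8 ug/mL, in the range 2 ug/mL to 30 ug/mL.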

Compound 4, solubility: < 1 ug/mL
Compound 4 gave a limit, no number; the forecaster's own chance of this, stated with the estimate: 10%; at least 8.0-fold (0.90 log units) between middle value and limit.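

In this assay, pyridin-3-yl in place of hydroxymethyl on a saturated chain carbon bound to an amide-type nitrogen reads as an at least 6.0-fold lower number from compound 2 to compound 4 (0.77 log units; beyond the scatter). Among these compounds, this is the first one-place step, and it shows that the number can move beyond the scatter at this position. Compound 4 stands at a limit of the assay, not at a number: the limit of < 1 ug/mL in this assay, at which 1 of the 4 values shown sits.

The compounds shown do not separate the loss of hydroxymethyl from the entry of pyridin-3-yl, and the full size of the step stays open. Also open, as far as these compounds go, is how a dimethylamino group or a carboxylic acid on the same chain would read in this assay.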